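Swapping a piperidine nitrogen substituent: alkyl to aryl carbonyl

The compounds below may be only part of what the source reports. "The series", "measured", "known", "first", "only" and "open" are said of these compounds alone.

Of the compounds shown here, two sharing one core have been measured in an ADME assay (liver) for metabolic stability, with Liver microsome (Homo sapiens) as the target, read by LC-MS, using microsomes and NADPH, tested at 1 uM; on this read-out lower numbers stand for a shorter-lived compound and higher numbers for a longer-lived compound. Compound 1 `CC(C)(C)c1cc(NC(=O)[C@@H]2CCCCN2CC2CC2)no1` gives 0.15 h. Compound 2 `CC(C)(C)c1cc(NC(=O)[C@@H]2CCCCN2CC2CCOCC2)no1` gives 0.183 h, the higher of the two numbers, though the step of a 1.2-fold higher number from compound 1 to compound 2 (0.09 log units; within the scatter) lies within the scatter, so the two cannot be told apart. Compound 3 `CC(C)(C)c1cc(NC(=O)[C@@H]2CCCCN2C(=O)c2ccc(Cl)cc2)no1` is not yet measured. It differs from compound 2 by (4-chlorophenyl)carbonyl in place of (oxan-4-yl)methyl on an amine nitrogen in a ring. Going by the values given here, the only measured step also exchanged the group on that same ring nitrogen, and the step of a 1.2-fold higher number from compound 1 to compound 2 (0.09 log units; within the scatter) was within the scatter. Among the compounds with values here, no measured pair exchanges an alkyl group for a carbonyl-linked aromatic group on this nitrogen, so the direction of this change is not covered by the data. A modest rise of a 2.2-fold higher number from compound 2 to compound 3 (0.34 log units; beyond the scatter) is expected, with wide uncertainty. Compound 3 is estimated at 0.4 h, within a range from 0.15 h to 1.2 h.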

Compound 3, half-life: 1.25 h
For compound 3 the middle estimate is 3.1-fold (0.49 log units) below the measured one; the measured number lies above the stated range.
By their numbers in this assay, from the lowest: compounds 1 and 2 (each within the scatter of the next); then compound 3.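

In this assay, the group on the ring nitrogen now proves able to shift the half-life clearly: the earlier exchange of one alkyl-type group for another stayed within the scatter, whereas (4-chlorophenyl)carbonyl in place of (oxan-4-yl)methyl gives a 6.8-fold higher number from compound 2 to compound 3 (0.83 log units; beyond the scatter). The same replacement of cyclopropylmethyl gives an 8.3-fold higher number from compound 1 to compound 3 (0.92 log units; beyond the scatter), so the rise appears against both of these groups. No measurement at hand gives the reason for this rise.

The carbonyl link and the 4-chlorophenyl ring entered together, so the compounds shown do not separate what each contributes. Still open, on these data alone, is how a plain phenylcarbonyl group without the chlorine, or a 4-chlorobenzyl group without the carbonyl, would read on the same nitrogen in this assay.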